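The source may hold more compounds than are shown below. What is called first, only, known or untested is meant among the compounds shown, and "the series" means these compounds.

Measured so far:
- compound 1, `O=C(OC1(C(=O)Nc2ccc([N+](=O)[O-])cc2)CCCCC1)c1ccc(Cl)cc1`, gives 355 nM in an ADME assay on WI-38 cells (Homo sapiens) for inhibition, read by MTT assay, with a stated time of 72 h; on this read-out higher numbers stand for weaker inhibition and lower numbers for stronger inhibition
- compound 2, `O=COC1(C(=O)Nc2ccc([N+](=O)[O-])cc2)CCCCC1`, gives 46.3 nM in this assay

Among the compounds with values here, compound 2 stands at the lowest of the two numbers; its nearest neighbour is compound 1, and the only measured step between them is a 7.7-fold lower number from compound 1 to compound 2 (0.88 log units; beyond the scatter), which came with hydrogen in place of 4-chlorophenyl on a carbonyl carbon.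

Compound 3, `CC(=O)Oc1ccccc1C(=O)OC1(C(=O)Nc2ccc([N+](=O)[O-])cc2)CCCCC1`, is not yet measured. It differs from compound 2 by 2-acetoxyphenyl in place of hydrogen on a carbonyl carbon. Within the data shown here, the one step that bears on this change is a 7.7-fold lower number from compound 1 to compound 2 (0.88 log units; beyond the scatter), which ran the other way: taking an aromatic group off that carbonyl carbon gave a lower number, beyond the scatter. Putting an aromatic group back onto the same carbonyl carbon is therefore expected to give a higher number, by a step of roughly that size, though the group entering here is not the one that left there, so the size is uncertain. For compound 3 the value is expected to be 250 nM, within a range from 80 nM to 800 nM. The step this estimate implies is expected to be a 5.4-fold higher number from compound 2 to compound 3 (0.73 log units; beyond the scatter).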

Compound 3, half-maximal inhibitory concentration: 48.4 nM
Estimate against measurement, compound 3: 5.2-fold (0.71 log units) above; the measured number lies below the stated range.
By their numbers in this assay, from the lowest: compounds 2 and 3 (each within the scatter of the next); then compound 1.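

In this assay, an aromatic group on this carbonyl carbon does not by itself move the number, since the step is a 1.0-fold higher number from compound 2 to compound 3 (0.02 log units; within the scatter) and leaves 2-acetoxyphenyl and hydrogen indistinguishable here. The earlier pair alone could have suggested that any aromatic group at this place gives weaker inhibition, but the change between the two aromatic groups is a 7.3-fold lower number from compound 1 to compound 3 (0.87 log units; beyond the scatter) and shows that the identity of the group matters. Among these three compounds, then, 4-chlorophenyl is the one group that stands apart, and no measurement shown here explains why it differs from 2-acetoxyphenyl.

Still open, going by these compounds, is whether the result for compound 3 comes from the benzene ring itself or from the acetoxy group it carries, which a plain phenyl or a 2-hydroxyphenyl group at the same carbonyl carbon could help to separate. Also open, on these data alone, is how a small methyl group, an amine or a carboxylic acid would read at this place, and whether 4-chlorophenyl stays apart from such groups.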